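Cyclopropyl for Cyclopropylmethyl on the Amide Nitrogen

This account rests on a few compounds, and the source may have more. Where it says the series, first, only, none or still open, it means among the compounds named here.

Compound 1, `O=C(/C=C1\CCc2cc(Cl)ccc21)NC1CC1`: 17%
Compound 2, `O=C(/C=C1\CCc2ccc(F)cc21)NCC1CC1`: 50%
Compound 3, `Cc1cccc2c1/C(=C/C(N)=O)CC2`: 100%

In a functional assay on the whole organism with Mus musculus as the target, at a dose of 100 mg/kg by the intraperitoneal route (a higher number here means more inhibition at the dose given (going by the name of the read-out), a lower number less inhibition), compound 2 gives 50%, the second highest of the three numbers. Compound 1 lies nearest to it, lower by a margin beyond the usual scatter, while compound 3 lies furthest, higher by a margin also beyond the scatter. Compound 4, `O=C(/C=C1\CCc2ccc(F)cc21)NC1CC1`, has not yet been measured. It differs from compound 2 in one place: cyclopropyl in place of cyclopropylmethyl on an amide-type nitrogen. Within the data shown here, no pair among the measured compounds differs in a single place, so no comparable step is known, and the expectation rests on compound 2 alone. In this assay the step is expected to be a number 8 percentage points lower from compound 2 to compound 4 (within the scatter), small and downward, not clearly beyond the scatter. Compound 4 is thus expected to give about 42%, within a range from 15% to 70%.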

Compound 4, a percentage reported as inhibition, in the whole organism at one dose (the size of the read-out at that dose, not a potency): 100%
Beside the measured number, compound 4's estimate is 58 percentage points below it; measured number outside the range, above it.
By their numbers in this assay, from the lowest: compound 1; then compound 2; then compounds 3 and 4 (each within the scatter of the next).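

Exchanging cyclopropylmethyl for cyclopropyl on the amide-type nitrogen gives, in this assay, a number 50 percentage points higher from compound 2 to compound 4 (beyond the scatter). Among these compounds, this is the first single-place step, and it shows that, with the rest of the structure unchanged, the group on this nitrogen can strongly alter the read-out. Nothing available explains the size of this step.

On these data alone, it remains open how a cyclobutyl or isopropyl group on this nitrogen would read. As far as these compounds go, it is also open whether the same exchange would give a similar step on a core carrying chlorine instead of fluorine.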